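Swapping 2-hydroxyphenyl for 4-hydroxyphenyl on the imine series

The source may hold more compounds than are shown below. What is called first, only, known or untested is meant among the compounds shown, and "the series" means these compounds.

In a functional assay on cells (Homo sapiens) for cytotoxicity, read by MTT assay, with a stated time of 24 h (a higher number here means a weaker inhibitor, a lower number a stronger inhibitor), compound 1 (`CCCCCCCCCCCCCCNC(=O)[C@H](CO)/N=C/c1ccc(OC)cc1`) gives 28100 nM, compound 2 (`CCCCCCCCCCCCCCNC(=O)[C@H](CO)/N=C/c1ccccc1[N+](=O)[O-]`) gives 21700 nM and compound 3 (`CCCCCCCCCCCCCCNC(=O)[C@H](CO)/N=C/c1ccccc1O`) gives 19000 nM. Compound 3 stands within the scatter of both other compounds, and nothing separates the three on these numbers: the measured steps are a 1.1-fold lower number from compound 2 to compound 3 (0.06 log units; within the scatter) and a 1.5-fold lower number from compound 1 to compound 3 (0.17 log units; within the scatter), and the remaining one is a 1.3-fold lower number from compound 1 to compound 2 (0.11 log units; within the scatter).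

The next compound is compound 4 (`CCCCCCCCCCCCCCNC(=O)[C@H](CO)/N=C/c1ccc(O)cc1`), which differs from compound 3 by 4-hydroxyphenyl in place of 2-hydroxyphenyl on a carbon with a double bond to nitrogen.

Among the measured compounds shown here, no measured pair isolates this exact exchange. The closest evidence is a 1.5-fold lower number from compound 1 to compound 3 (0.17 log units; within the scatter), which links a 4-methoxyphenyl compound to the 2-hydroxyphenyl compound, and a 1.1-fold lower number from compound 2 to compound 3 (0.06 log units; within the scatter), which exchanges nitro for hydroxy on the aromatic ring. Both stay within the scatter, so the three aryl groups tested so far give no measurable spread in this assay. No step beyond the scatter is therefore expected, and the expected step is a 1.2-fold higher number from compound 3 to compound 4 (0.06 log units; within the scatter). For compound 4 the estimated value is 22000 nM, with an expected range of 13000 nM to 36000 nM.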

Compound 4, half-maximal inhibitory concentration: 19300 nM
The estimate for compound 4 lay 1.1-fold (0.06 log units) above the measured number, and the stated range covers the measured number.
By their numbers in this assay, from the lowest: compounds 3, 4, 2 and 1 (each within the scatter of the next).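

In this assay, among the compounds shown here, the exchange of 2-hydroxyphenyl for 4-hydroxyphenyl on a carbon with a double bond to nitrogen is the first pair that has the same atoms joined differently, and a 1.0-fold higher number from compound 3 to compound 4 (0.01 log units; within the scatter) shows that this rearrangement leaves no measurable mark on the number. The other two new steps agree: a 1.1-fold lower number from compound 2 to compound 4 (0.05 log units; within the scatter) for 4-hydroxyphenyl in place of 2-nitrophenyl and a 1.5-fold lower number from compound 1 to compound 4 (0.16 log units; within the scatter) for hydrogen in place of methyl on an oxygen on an aromatic ring both stay within the scatter, so the four aryl groups shown cannot be told apart in this assay. Nothing measured here offers an explanation for this lack of spread.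

Still open, as far as these compounds go, is whether an aryl group carrying an amine or a carboxylic acid would give a step beyond the scatter, or whether these four compounds simply sample too narrow a set of groups to show one. Also open, from the compounds shown here alone, is how the number responds to a change outside the aryl group, such as a shorter chain on the core of compound 4.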